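Methoxycarbonyl to ethoxycarbonyl on the shared core

The source may report more compounds than this note shows. Statements on the series, on what has been measured and on what is new or still open speak of the compounds shown alone.

Measured in a functional assay on the whole organism with Scenedesmus acutus as the target; on this read-out higher numbers stand for weaker inhibition and lower numbers for stronger inhibition:
- compound 1 `O=C1C2=C(CCCC2)C(=O)N1c1ccc(Cl)cc1F`: 24.6 nM
- compound 2 `O=C(O)c1cc(N2C(=O)C3=C(CCCC3)C2=O)c(F)cc1Cl`: 759 nM
- compound 3 `COC(=O)c1cc(N2C(=O)C3=C(CCCC3)C2=O)c(F)cc1Cl`: 110 nM

Compound 3 holds the middle of the three numbers, with compound 1 lower and compound 2 higher. Compound 4 `CCOC(=O)c1cc(N2C(=O)C3=C(CCCC3)C2=O)c(F)cc1Cl` differs from it by methyl in place of hydrogen on a saturated chain carbon bound to an oxygen next to a carbonyl group. The closest measured change is a 6.9-fold lower number from compound 2 to compound 3 (0.84 log units; beyond the scatter). Further off lie a 4.5-fold higher number from compound 1 to compound 3 (0.65 log units; beyond the scatter) and a 31-fold higher number from compound 1 to compound 2 (1.49 log units; beyond the scatter). None of these extends an existing methoxycarbonyl, so no change beyond the scatter is expected in this assay. The expected step is a 1.1-fold higher number from compound 3 to compound 4 (0.04 log units; within the scatter). Compound 4 is estimated at 120 nM, with an expected range of 50 nM to 280 nM.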

Compound 4, half-maximal inhibitory concentration: 100 nM
Compound 4: the middle estimate sits 1.2-fold (0.08 log units) above what was measured; the measured number falls inside the stated range.
By their numbers in this assay, from the lowest: compound 1; then compounds 4 and 3 (each within the scatter of the next); then compound 2.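

In this assay the step from methoxycarbonyl to ethoxycarbonyl gives a 1.1-fold lower number from compound 3 to compound 4 (0.04 log units; within the scatter) and so leaves the read-out unchanged within the scatter. The two other steps, a 7.6-fold lower number from compound 2 to compound 4 (0.88 log units; beyond the scatter) and a 4.1-fold higher number from compound 1 to compound 4 (0.61 log units; beyond the scatter), both lie beyond the scatter and place compound 4 where compound 3 already stood, apart from the carboxylic acid and from compound 1. Nothing available gives a reason for this tolerance of the added methyl.

Going by these compounds, whether a longer chain such as propoxycarbonyl, or a primary amide in place of the ester, holds this level stays open. Also open, on these data alone, is whether any group here can match compound 1.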